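A few compounds are considered here, and "the series" means these few. Any claim that something is new, unique, unknown or untested is made for them only; others in the source may bear on it.

In a functional assay on HepG2 cells (Homo sapiens) for antiproliferative activity, read by XTT assay, with a stated time of 72 h (a lower number here means a stronger inhibitor, a higher number a weaker inhibitor), three nucleosides built on a shared core have been measured, and none of them gives a number. Compound 1 `Cc1ncnc2c1c(-c1cccs1)cn2[C@@H]1O[C@H](CO)[C@@H](O)[C@H]1O` reaches only a limit, > 15000 nM. Compound 2 `Nc1nc(N)c2c(-c3ccco3)cn([C@@H]3O[C@H](CO)[C@@H](O)[C@H]3O)c2n1` also reaches only a limit, > 20000 nM. Going by these compounds, compound 3 `Cc1nc(N)c2c(-c3ccco3)cn([C@@H]3O[C@H](CO)[C@@H](O)[C@H]3O)c2n1` likewise stands at a limit, > 20000 nM, so its true place on the scale is unknown.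

Compound 4 `Cc1nc(N)c2c(-c3ccoc3)cn([C@@H]3O[C@H](CO)[C@@H](O)[C@H]3O)c2n1` differs from compound 3 in one group: furan-3-yl in place of furan-2-yl on an aromatic carbon. Going by the values given here, the only measured step, a step that the two limits leave unreadable from compound 2 to compound 3, concerns a different place on the core and offers no size to carry over. No measured pair tests furan-3-yl in place of furan-2-yl, so the data give no reason to expect a step beyond the scatter in this assay, in either direction. The expectation therefore starts from compound 3, whose limit is > 20000 nM. The expected step is a number no higher from compound 3 to compound 4 (the limit leaves the size open). Compound 4 is estimated at 20000 nM, with an expected range of 8000 nM to 40000 nM.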

Compound 4, half-maximal inhibitory concentration: > 20000 nM
Compound 4 gave a limit, no number; the forecaster's own chance of this, stated with the estimate: 85%; the middle value lies on the limit itself.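

Compound 3 and compound 4 each give only a limit, so no step can be read between them: the limit of > 20000 nM in this assay, at which 3 of the 4 values shown sit.

The compounds shown leave open whether furan-3-yl and furan-2-yl differ at all on the shared core, and where any of these compounds truly stands.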